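Amine swap in a coumarin ether series: piperidine to methylpiperazine

The source may report more compounds than this note shows. Statements on the series, on what has been measured and on what is new or still open speak of the compounds shown alone.

Compound 1 `CCN(CC)CC(O)COc1ccc2oc(=O)cc(C)c2c1`: 0.0085 ug/mL
Compound 2 `Cc1cc(=O)oc2ccc(OCC(O)CN3CCCCC3)cc12`: 0.0083 ug/mL

In a functional assay on ileum for antagonist activity at histamine H1 receptor (Cavia porcellus), tested at 1 mg/mL (on this read-out lower numbers stand for an effect already at smaller amounts and higher numbers for an effect only at larger amounts of compound), compound 2 gives 0.0083 ug/mL, a number that sits within the scatter of compound 1. Within the data shown here, the one measured step, a 1.0-fold lower number from compound 1 to compound 2 (0.01 log units; within the scatter), shows that exchanging one amine for another at this position left the read-out unchanged. Compound 3 `Cc1cc(=O)oc2ccc(OCC(O)CN3CCN(C)CC3)cc12` carries 4-methylpiperazin-1-yl in place of piperidin-1-yl on a saturated chain carbon, two bonds along the chain from an oxygen on a saturated carbon. Among the measured compounds shown here, no measured step covers this particular change, so only the flat result of the first step bears on it. A modest weakening is expected, a 1.4-fold higher number from compound 2 to compound 3 (0.16 log units; within the scatter), giving an estimate for compound 3 of 0.012 ug/mL with a range from 0.004 ug/mL to 0.04 ug/mL.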

Compound 3, half-maximal effective concentration: 0.0081 ug/mL
For compound 3 the middle estimate is 1.5-fold (0.17 log units) above the measured one; low and high end bracket the measured number.
By their numbers in this assay, from the lowest: compounds 3, 2 and 1 (each within the scatter of the next).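

In this assay, 4-methylpiperazin-1-yl in place of piperidin-1-yl gives a 1.0-fold lower number from compound 2 to compound 3 (0.01 log units; within the scatter) and, set against diethylamino, gives a 1.0-fold lower number from compound 1 to compound 3 (0.02 log units; within the scatter) as well. At this saturated chain carbon, then, a ring with a second nitrogen and a methyl group leaves the read-out within the scatter, so all three amines now stand level. Nothing measured here explains this flat result.

Going by these compounds, it remains open whether morpholine, a primary amine or a carboxylic acid at this carbon would hold the read-out. The same applies to a longer chain carrying the amine.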